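This account rests on a few compounds, and the source may have more. Where it says the series, first, only, none or still open, it means among the compounds named here.

Compound 3 `Cn1cncc1C(OCc1ccc(C#N)cc1/C=C/c1ccc([N+](=O)[O-])cc1)c1ccc(C#N)cc1` gives 2.24 nM in a functional assay on NIH3T3 cells (Mus musculus) (a higher number here means that more compound is needed for the effect, a lower number that less compound is needed), the lowest of the two numbers shown. Going by the values given here, compound 1 `Cn1cncc1C(OCc1ccc(C#N)cc1-c1ccccc1)c1ccc(C#N)cc1` gives 140 nM in this assay, and a 63-fold lower number from compound 1 to compound 3 (1.80 log units; beyond the scatter) is the only step whose size can be read. Compound 2 `CCCCCCC#Cc1cc(C#N)ccc1COC(c1ccc(C#N)cc1)c1cncn1C` reaches only a limit of the assay, > 0.1 nM. Hence a step that the limit leaves unreadable from compound 1 to compound 2 and a step that the limit leaves unreadable from compound 2 to compound 3 give no size, as the limit of > 0.1 nM in this assay, at which 1 of the 3 values shown sits, shows. Compound 4 `Cn1cncc1C(OCc1ccc(C#N)cc1C#Cc1ccc([N+](=O)[O-])cc1)c1ccc(C#N)cc1` differs from compound 3 by 2-(4-nitrophenyl)ethynyl in place of 2-(4-nitrophenyl)ethenyl on an aromatic carbon. Among the compounds with values here, no measured step changes this linker alone; compound 2 shows only that a triple bond on an aromatic carbon is tolerated. The step of a 1.1-fold lower number from compound 3 to compound 4 (0.05 log units; within the scatter) is thus expected to stay within the scatter. Compound 4 is estimated at 2 nM, between 0.5 nM and 8 nM.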

Compound 4, half-maximal effective concentration: 36 nM
Compound 4: the middle estimate sits 18-fold (1.26 log units) below what was measured; measured number outside the range, above it.
By their numbers in this assay, from the lowest: compound 3; then compound 4; then compound 1.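

In this assay, the linker at this position matters on its own, with the 4-nitrophenyl end held constant: a 16-fold higher number from compound 3 to compound 4 (1.21 log units; beyond the scatter). The 2-(4-nitrophenyl)ethynyl group still gives a lower number than phenyl on this aromatic carbon: a 3.9-fold lower number from compound 1 to compound 4 (0.59 log units; beyond the scatter). Compound 2 stands at a limit, so the steps that involve it cannot be read: the limit of > 0.1 nM in this assay, at which 1 of the 4 values shown sits.

The compounds shown leave open whether the gap between the two linkers persists with another end group, such as an amine or a carboxylic acid in place of the nitro group.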